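The source may hold more compounds than are shown below. What is called first, only, known or untested is meant among the compounds shown, and "the series" means these compounds.

Working notes on the series.

The shared core is carried by compound 1 `N=C(Nc1ccccc1)c1cc2c(-c3ccccc3)n[nH]c2c(NC2CCCCC2)n1`, by compound 3 `COc1ccc(Cn2nc(-c3ccccc3)c3cc(C(=N)Nc4ccccc4)nc(NC4CCCCC4)c32)cc1`, by compound 2 `COc1ccc(Cn2nc(-c3ccccc3)c3cc(C(=N)Nc4cccc(C(F)(F)F)c4)nc(Nc4cc(OC)c(OC)c(OC)c4)c32)cc1` and by the as yet unmeasured compound 4 `COc1cc(Nc2nc(C(=N)Nc3cccc(C(F)(F)F)c3)cc3c(-c4ccccc4)n[nH]c23)cc(OC)c1OC`. The difference between the core of compound 3 and that of compound 2 is not broken down here.

In a functional assay on MDA-MB-231 cells (Homo sapiens) for cytotoxicity, read by MTT assay, with a stated time of 72 h (a lower number here means a stronger inhibitor, a higher number a weaker inhibitor), compound 1 gives 1710 nM. In this assay compound 3 gives 3400 nM. For compound 2 only a limit of the assay is known in this assay, namely > 50000 nM; this is one of the values that sit at the limit of > 50000 nM in this assay, at which 1 of the 3 values shown sits.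

Among the measured compounds shown here, the one change that recurs is hydrogen in place of 4-methoxybenzyl on an aromatic nitrogen, which gave a 2.0-fold lower number from compound 3 to compound 1 (0.30 log units; within the scatter). The same kind of change, (hydrogen in place of 4-methoxybenzyl on an aromatic nitrogen), separates compound 2 from compound 4, and the two place descriptions agree word for word.

Given that the measured step from compound 3 to compound 1 stayed within the scatter, the step from compound 2 to compound 4 in this assay is expected to be of similar small size, a number no higher from compound 2 to compound 4 (the limit leaves the size open), resting on the measured step of a 2.0-fold lower number from compound 3 to compound 1 (0.30 log units; within the scatter). Since compound 2 itself is known only as a limit, the most likely outcome is that compound 4 is also reported as a limit rather than a number. The estimate for compound 4 in this assay is 50000 nM, with a range from 15000 nM to 200000 nM.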

Compound 4, half-maximal inhibitory concentration: 7600 nM
Compound 4: middle estimate off by 6.6-fold (0.82 log units), on the high side; measured number below the stated range.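

The replacement of 4-methoxybenzyl by hydrogen on the aromatic nitrogen gives an at least 6.5-fold lower number from compound 2 to compound 4 (0.81 log units; beyond the scatter) in this assay, and the size of the step does not carry over from one core to the other: the same change on two cores in this assay, a 2.0-fold lower number (0.30 log units; within the scatter) from compound 3 to compound 1 and an at least 6.5-fold lower number (0.81 log units; beyond the scatter) from compound 2 to compound 4, at least 3.3-fold (0.51 log units) apart, beyond the scatter of two such steps. Compound 2 is known only as a limit of the assay, so the new step fixes a minimum size and not an exact one: the limit of > 50000 nM in this assay, at which 1 of the 4 values shown sits. The two pairs show that a step measured on one core did not set the size of the same change on the other, but they do not show which difference between the cores goes with the gap, and they give no rule for any further core.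

Going by these compounds, it remains open whether a methyl group, a plain benzyl group or a longer alkyl chain on the same aromatic nitrogen would give a small step like that on the core of compound 3 or a larger one like that on the core of compound 2. Also open, on these data alone, is which part of the core governs the size of the step, for instance whether a cyclohexylamine in place of the trimethoxyphenyl amine on the core of compound 2 would bring the two steps together.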